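Benzoxazole sulfonamides: aryl swap on the sulfonyl sulfur

The compounds below may be only part of what the source reports. "The series", "measured", "known", "first", "only" and "open" are said of these compounds alone.

Measured so far in an assay on isolated protein for inhibition of malate dehydrogenase, mitochondrial (Sus scrofa), with stated times of 45 min and 30 min; a lower number here means a stronger inhibitor, a higher number a weaker inhibitor:
compound 1 `O=S(=O)(Nc1ccc2oc(-c3ccccc3)nc2c1)c1cccc(F)c1`, a limit only: > 63000 nM
compound 2 `O=S(=O)(Nc1ccc2oc(-c3ccccc3)nc2c1)c1ccccc1Cl`, a limit only: > 63000 nM

Compound 1 gives no number in this assay, only the limit > 63000 nM. Compound 2 likewise gives only a limit in this assay, > 63000 nM. The step that the two limits leave unreadable from compound 1 to compound 2 cannot be read, both values sitting at the limit of > 63000 nM in this assay, at which 2 of the 2 values shown sit. Compound 2 thus stands at the limit of this assay, without a number of its own.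

Compound 3 `COc1ccc(S(=O)(=O)Nc2ccc3oc(-c4ccccc4)nc3c2)cc1` differs from compound 2 by 4-methoxyphenyl in place of 2-chlorophenyl on a sulfonyl sulfur. Among the compounds with values here, the only measured step that touches the group on the sulfonyl sulfur is the unreadable one from compound 1 to compound 2, so the series gives no direction for this change. With both measured values at the limit, compound 3 is expected to give a limit again in this assay, and its estimate is 90000 nM with a range from 25000 nM to 400000 nM. The step that the limit leaves unreadable from compound 2 to compound 3 is accordingly estimated as none beyond the scatter.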

Compound 3, half-maximal inhibitory concentration: > 63000 nM
Compound 3 ended at the assay's limit; the forecaster's own chance of this, stated with the estimate: 85%; the middle value lies beyond the limit too.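

Compound 3 also sits at the limit, so neither its step from compound 1 nor its step from compound 2 can be read: the limit of > 63000 nM in this assay, at which 3 of the 3 values shown sit.

As far as these compounds go, whether any aryl group on the sulfonyl sulfur gives a measurable value in this assay remains open.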